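Methoxy to hydroxy step carried onto a second core

The compounds below may be only part of what the source reports. "The series", "measured", "known", "first", "only" and "open" are said of these compounds alone.

Working notes on the series in a functional assay on U-373MG ATCC cells (Homo sapiens) for inhibition, read by colorimetric assay and MTT assay, with a stated time of 72 h; on this read-out higher numbers stand for weaker inhibition and lower numbers for stronger inhibition. Compound 1 `COc1ccc(C(=O)NNC(=S)Nc2csc(-c3ccccc3)c2)cc1` gives 41000 nM. Compound 2 `O=C(NNC(=S)Nc1csc(-c2ccccc2)c1)c1ccc(O)cc1` reaches only a limit of the assay, > 100000 nM. The change from compound 1 to compound 2 is hydrogen in place of methyl on an oxygen on an aromatic ring; it brought an at least 2.4-fold higher number from compound 1 to compound 2 (0.38 log units; beyond the scatter), a figure that is a lower bound because of the limit of > 100000 nM in this assay, at which 1 of the 3 values shown sits. Compound 3 `COc1ccc(-c2nnc(Nc3csc(-c4ccccc4)c3)s2)cc1` has a core that differs from that of compound 1 in a way not broken down here. In this assay compound 3 gives 92000 nM, the highest of the two numbers shown. Compound 4 `Oc1ccc(-c2nnc(Nc3csc(-c4ccccc4)c3)s2)cc1` has not yet been measured; it differs from compound 3 by hydrogen in place of methyl on an oxygen on an aromatic ring, the same change at the same place as the one between compound 1 and compound 2, and this is one of only two instances of the change among the compounds shown. The expected step is a 2.4-fold higher number from compound 3 to compound 4 (0.38 log units; beyond the scatter), which rests on an at least 2.4-fold higher number from compound 1 to compound 2 (0.38 log units; beyond the scatter) and on compound 3 already standing at 92000 nM. Compound 4 is therefore expected to fall at 220000 nM, between 100000 nM and 500000 nM, and most likely to be reported only as a limit.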

Compound 4, half-maximal inhibitory concentration: 58000 nM
Beside the measured number, compound 4's estimate is 3.8-fold (0.58 log units) above it; the measured number lies below the stated range.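

In this assay, the same hydrogen in place of methyl on an oxygen on an aromatic ring gave a 1.6-fold lower number from compound 3 to compound 4 (0.20 log units; within the scatter), so the step seen on the core of compound 1 did not carry over to the core of compound 3: the same change on two cores in this assay, an at least 2.4-fold higher number (0.38 log units; beyond the scatter) from compound 1 to compound 2 and a 1.6-fold lower number (0.20 log units; within the scatter) from compound 3 to compound 4, at least 3.8-fold (0.58 log units) apart, beyond the scatter of two such steps. The step on the core of compound 1 is only a bound, as compound 2 stands at a limit of the assay: the limit of > 100000 nM in this assay, at which 1 of the 4 values shown sits. The two instances show that the outcome of this change depends on the core in this small set, but they do not separate compound 3 from compound 4, and they do not show which part of the core accounts for the difference.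

Still open is whether either behaviour extends to further cores, since the two cores shown differ in a way not broken down here. Also open, from the compounds shown here alone, is how an amine or a carboxylic acid in place of the hydroxy of the 4-hydroxyphenyl group would behave on each core.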